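The source may hold more compounds than are shown below. What is called first, only, known or untested is meant among the compounds shown, and "the series" means these compounds.

Measured so far in a functional assay on DU-145 cells (Homo sapiens) for inhibition, read by trypan blue exclusion, with a stated time of 96 h; on this read-out higher numbers stand for weaker inhibition of growth and lower numbers for stronger inhibition of growth:

- compound 1 `O=C(/C(=C\c1csc([N+](=O)[O-])c1)S(=O)(=O)c1ccc(Br)cc1)c1ccc(Br)cc1`: 1000 nM
- compound 2 `CN(C)c1ccc(/C=C(\C(=O)c2ccc(C(=O)O)cc2)S(=O)(=O)Cc2ccc(Cl)cc2)cc1`: > 100000 nM, a limit of this assay rather than a number
- compound 3 `Cc1ccc(/C=C(\C(=O)c2ccc(Cl)cc2)S(=O)(=O)Cc2ccc(Cl)cc2)s1`: 1000 nM

Where compound 1 stands: at the digits shown, compound 1 sits level with compound 3, the two values lying within the usual scatter of each other, so no order between them can be read. Compound 2 stands apart only as a limit (the limit of > 100000 nM in this assay, at which 1 of the 3 values shown sits), and nothing finer is known of it.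

The next compound, compound 4 `O=C(/C(=C\c1ccc(Br)cc1)S(=O)(=O)c1ccc(Br)cc1)c1ccc(Br)cc1`, has not been measured in this assay. It is derived from compound 1 by one change: 4-bromophenyl in place of 5-nitrothiophen-3-yl on a double-bonded chain carbon bound to a double-bonded chain carbon. Among the measured compounds shown here, no measured pair in the set isolates a change of this kind, so the size of the step has to be guessed from the spread of the three values rather than from a comparable step. Going by these compounds, both compound 1 and compound 3 carry a five-membered aromatic ring on the double-bonded chain carbon and give the same figure; what a six-membered carbon ring does at that place is untested here.

The expectation is that the step from compound 1 to compound 4 in this assay, a 2.0-fold higher number from compound 1 to compound 4 (0.30 log units; within the scatter), will be small and could fall either way within the scatter, with a slight lean toward weaker inhibition of growth. Compound 4 is therefore estimated at 2000 nM, with a range from 500 nM to 8000 nM.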

Compound 4, concentration for 50% growth inhibition: 10000 nM
Compound 4: the middle estimate sits 5.0-fold (0.70 log units) below what was measured; the whole stated range lies below it.
By their numbers in this assay, from the lowest: compounds 1 and 3 (each within the scatter of the next); then compound 4. At a limit, above all of these: compound 2.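

In this assay, the group on a double-bonded chain carbon bound to a double-bonded chain carbon clearly affects the read-out: 4-bromophenyl in place of 5-nitrothiophen-3-yl gives a 10-fold higher number from compound 1 to compound 4 (1.00 log units; beyond the scatter), which means weaker inhibition of growth. Among the compounds shown here, this is the first step that isolates a single place, with the rest of compound 1 unchanged, so the position can now be treated as sensitive to this exchange. The ring size, the ring hetero atom and the nitro group all change at once, however, and no measurement shown assigns the step to any one of them.

Going by these compounds, it remains open whether the nitro group or the five-membered aromatic ring carries the difference, and a plain thiophen-3-yl and a 4-nitrophenyl at this place would separate the two. On these data alone, it is also open how a basic ring such as pyridin-3-yl, or an amine such as morpholin-4-yl, would stand on the same carbon with the rest of compound 1 kept.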